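Thioamide chain variation on the shared core: compound 4

The compounds below may be only part of what the source reports. "The series", "measured", "known", "first", "only" and "open" are said of these compounds alone.

Compound 3 `N=C(S)CCCCCCn1nc(-c2ccccc2)ccc1=O` stands second highest of the three numbers in a functional assay on the whole organism (stomach) for inhibition, with Rattus norvegicus as the target, at a dose of 100 mg/kg by the intraduodenal route (a lower number here means less inhibition, a higher number more inhibition at the dose given (going by the name of the read-out)), giving 33.9%. Above it lies compound 1 `CC/N=C(\S)CCn1nc(-c2ccccc2)ccc1=O` with 50.3%; below it compound 2 `NC(=O)CCn1nc(-c2ccccc2)ccc1=O` with -2.8%. The measured steps show that the terminal group matters: a number 53.1 percentage points lower from compound 1 to compound 2 (beyond the scatter), while lengthening the chain gave a number 16.4 percentage points lower from compound 1 to compound 3 (beyond the scatter), and a number 36.7 percentage points higher from compound 2 to compound 3 (beyond the scatter).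

Compound 4 `CN(C)C(=S)CCCCCn1nc(-c2ccccc2)ccc1=O` differs from compound 3 by a group of 5 heavy atoms (3 carbon, 1 nitrogen, 1 sulfur; no ring) in place of a group of 4 heavy atoms (2 carbon, 1 nitrogen, 1 sulfur; no ring), on a saturated chain carbon, five bonds along the chain from an aromatic nitrogen. Among the measured compounds shown here, no measured pair tests this particular exchange; the steps to hand concern the thioamide against an amide and the chain length, both at the thioamide end of the chain. Since the sulfur-bearing group is kept and the chain is of like size, no step beyond the scatter is expected in this assay, with the direction left open. Compound 4 is therefore estimated at 35%, within 15% to 55%, which is expected to mean a number 1.1 percentage points higher from compound 3 to compound 4 (within the scatter).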

Compound 4, a percentage reported as inhibition, in the whole organism at one dose (the size of the read-out at that dose, not a potency): 58.2%
Beside the measured number, compound 4's estimate is 23.2 percentage points below it; the measured number lies above the stated range.
By their numbers in this assay, from the lowest: compound 2; then compound 3; then compounds 1 and 4 (each within the scatter of the next).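

In this assay, the change at this position is not neutral even though the sulfur-bearing end is kept: the step is a number 24.3 percentage points higher from compound 3 to compound 4 (beyond the scatter). Keeping sulfur in the terminal group therefore does not fix the number, a point the earlier steps could not show, since the change from thioamide to amide in compound 2 also removed the sulfur. The group that enters has 0 hydrogen-bond donors and the group that leaves has 2, but no measurement here explains the gain.

The compounds shown do not separate the loss of those donors from the change in chain and heavy-atom count. Also open, as far as these compounds go, is how an amine, a carboxylic acid or a longer chain at this position would read in this assay.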